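The source may hold more compounds than are shown below. What is called first, only, known or untested is meant among the compounds shown, and "the series" means these compounds.

- Compound 1 `CCCCNc1cccc(N2C[C@@H](c3ccc(OC)c(OC4CCCC4)c3)CC2=O)c1`: > 10000 nM, a limit
- Compound 2 `COc1ccc([C@H]2CC(=O)N(c3cccc(NS(=O)(=O)c4cccc(OC(F)(F)F)c4)c3)C2)cc1OC1CCCC1`: > 10000 nM, a limit

Both compounds were tested in a functional assay on HEK293 cells (Homo sapiens) for cytotoxicity; on this read-out lower numbers stand for higher toxicity in this test and higher numbers for lower toxicity in this test. Compound 2 stands at the limit of > 10000 nM in this assay, at which 2 of the 2 values shown sit, which is a limit and not a number. Compound 3 `COc1ccc([C@H]2CC(=O)N(c3cccc(NS(=O)(=O)c4cc(C)ccc4OC)c3)C2)cc1OC1CCCC1` carries 2-methoxy-5-methylphenyl in place of 3-(trifluoromethoxy)phenyl on a sulfonyl sulfur. Going by the values given here, no measured step shows what such a change does. Since both measured compounds sit at the limit of > 10000 nM in this assay, at which 2 of the 2 values shown sit, no change beyond the scatter is expected in this assay. The expected step is a step that the limit leaves unreadable from compound 2 to compound 3. Compound 3 is estimated at 12000 nM, with an expected range of 6000 nM to 30000 nM.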

Compound 3, half-maximal cytotoxic concentration: > 10000 nM
Compound 3 was reported as a limit; the forecaster's own chance of this, stated with the estimate: 85%; the middle value does not contradict the limit.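

The steps from compound 2 and from compound 1 to compound 3 cannot be read in this assay, because all three values are limits: the limit of > 10000 nM in this assay, at which 3 of the 3 values shown sit.

The compounds shown leave open whether any structural change alters toxicity in this assay, and at what concentration compound 1, compound 2 or compound 3 would become toxic.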